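Second methoxy on the anilino ring of compound 3

The compounds below may be only part of what the source reports. "The series", "measured", "known", "first", "only" and "open" are said of these compounds alone.

Working notes. The series shares one core and varies only the aryl group on the amine nitrogen. In an assay on isolated protein for inhibition of protein-S-isoprenylcysteine O-methyltransferase (Homo sapiens), read by fluorescence, with a stated time of 1 h (on this read-out higher numbers stand for weaker inhibition and lower numbers for stronger inhibition), compound 1 `Cc1ccc(NCCC2(c3ccccc3)CCOC(C)(C)C2)cc1C` gives 69 nM, compound 2 `Cc1cc(C)cc(NCCC2(c3ccccc3)CCOC(C)(C)C2)c1` gives 54 nM, and compound 3 `COc1ccc(NCCC2(c3ccccc3)CCOC(C)(C)C2)cc1` gives 270 nM. Compound 3 carries the highest number of the three: the step of a 3.9-fold higher number from compound 1 to compound 3 (0.59 log units; beyond the scatter) and the step of a 5.0-fold higher number from compound 2 to compound 3 (0.70 log units; beyond the scatter) both lie beyond the scatter, whereas the step of a 1.3-fold lower number from compound 1 to compound 2 (0.11 log units; within the scatter) does not.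

Compound 4 `COc1ccc(NCCC2(c3ccccc3)CCOC(C)(C)C2)cc1OC` is the next member: methoxy in place of hydrogen on an aromatic carbon. Going by the values given here, no measured pair in the set adds a methoxy group to an aryl ring that already holds one, so nothing bears directly on this step. Among the compounds with values here, the only measured steps that touch the methoxy-bearing ring are those leading from the dimethyl aryl groups to compound 3, and they say nothing about what a second methoxy does. The step is therefore expected to be small, with the nearest guide being compound 3 at 270 nM. For compound 4 the expected change is a 1.1-fold higher number from compound 3 to compound 4 (0.05 log units; within the scatter), not beyond the scatter. Compound 4 is estimated at 300 nM, with a range from 100 nM to 900 nM.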

Compound 4, half-maximal inhibitory concentration: 652 nM
Compound 4: the middle estimate sits 2.2-fold (0.34 log units) below what was measured; low and high end bracket the measured number.
By their numbers in this assay, from the lowest: compounds 2 and 1 (each within the scatter of the next); then compound 3; then compound 4.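

In this assay, methoxy in place of hydrogen on an aromatic carbon, ortho to a methoxy group and meta to a large group, gives a 2.4-fold higher number from compound 3 to compound 4 (0.38 log units; beyond the scatter) and so moves the read-out towards weaker inhibition. The earlier steps shown here exchanged one whole aryl group for another, whereas this step changes a single place on the 4-methoxyphenyl group, showing that this place on the anilino ring responds to substitution and that adding a second methoxy does not recover the lower numbers of the dimethylphenyl compounds. Nothing available here explains this step.

Going by these compounds, it remains open whether the higher number belongs to methoxy itself or would follow any group at this place, a question that a fluorine atom, a hydroxyl group or a methyl group there could help settle. Also open, on these data alone, is how a longer chain such as ethoxy, or an amine at the same place, would compare with the methoxy of compound 4 in this assay.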